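Triazole-linked coumarin dienones: one aromatic methoxy removed

The source may hold more compounds than are shown below. What is called first, only, known or untested is meant among the compounds shown, and "the series" means these compounds.

Measured so far, in a functional assay on PC-3 cells (Homo sapiens) for inhibition, read by sulforhodamine B assay, with a stated time of 48 h, tested at 50 uM; a lower number here means less inhibition of growth, a higher number more inhibition of growth at the concentration tested:
compound 1, `COc1cccc(/C=C/C(=O)/C=C/c2ccc(OCc3cn(CCOc4cc(=O)oc5ccccc45)nn3)c(OC)c2)c1`, 13%
compound 2, `COc1ccc(/C=C/C(=O)/C=C/c2ccc(OCc3cn(CCOc4cc(=O)oc5ccccc45)nn3)c(OC)c2)cc1OC`, 19%
compound 3, `COc1ccccc1/C=C/C(=O)/C=C/c1ccc(OCc2cn(CCCCCOc3cc(=O)oc4ccccc34)nn2)c(OC)c1`, "not active" (no number reported), with no number given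

Compound 1 and compound 2 share a core and differ by hydrogen in place of methoxy on an aromatic carbon. The step of a number 6 percentage points lower from compound 2 to compound 1 (within the scatter) lies within the usual scatter of this assay, so the two values are not ordered against each other.

Compound 3 carries a different core; the difference between its core and that of compound 2 is not broken down here. For compound 3 only the verdict "not active" (no number reported) is available, without a number.

Compound 4, `COc1cc(/C=C/C(=O)/C=C/c2ccccc2)ccc1OCc1cn(CCCCCOc2cc(=O)oc3ccccc23)nn1`, is not yet measured. It differs from compound 3 by hydrogen in place of methoxy on an aromatic carbon. This is the same kind of change as from compound 2 to compound 1, not the same change: in compound 2 the leaving methoxy sits ortho to a methoxy group (2 heavy atoms) and para to a large group, whereas in compound 3 it sits ortho to a large group, on a ring with no other group named.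

The step from compound 3 to compound 4 is expected to be small, resting on compound 2 to compound 1, where a number 6 percentage points lower from compound 2 to compound 1 (within the scatter) stayed within the scatter, and on compound 3 being reported as not active. Compound 4 is therefore expected to give about 10% in this assay, estimated between 0% and 22%, with a real chance that again only "not active" is reported.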

Compound 4, percent growth inhibition at one concentration: "not active" (no number reported)
Compound 4: no number reported; there is nothing to compare the estimate with.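

In this assay, for the compounds shown here, compound 3 gives "not active" (no number reported) and compound 4 gives "not active" (no number reported), so no step between these two compounds can be read. No measured evidence bears on this result. The compounds shown leave open whether the change from 2-methoxyphenyl to phenyl alters growth inhibition on the core of compound 3, and how it would compare with the step of a number 6 percentage points lower from compound 2 to compound 1 (within the scatter).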